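A few compounds are considered here, and "the series" means these few. Any claim that something is new, unique, unknown or untested is made for them only; others in the source may bear on it.

Values in a functional assay on the whole organism (strain Wistar) for inhibition, with Rattus norvegicus as the target, read by paw edema, with stated times of 60 min and 6 h, at a dose of 100 mg/kg by the oral route; on this read-out lower numbers stand for less inhibition and higher numbers for more inhibition at the one dose given (going by the name of the read-out):
compound 1 `COc1cc2c(cc1OC)C(CC(N)=O)CC2`: 27.8%
compound 2 `CCNC(=O)CC1CCc2cc(OC)c(OC)cc21`: 20.4%
compound 3 `COc1cc2c(cc1OC)C(CC(=O)NC1CCCC1)CC2`: 40.7%

Compound 3 gives the highest of the three numbers: a number 12.9 percentage points higher from compound 1 to compound 3 (beyond the scatter) and a number 20.3 percentage points higher from compound 2 to compound 3 (beyond the scatter), both beyond the scatter, while a number 7.4 percentage points lower from compound 1 to compound 2 (within the scatter) stays within it. Compound 4 `COc1cc2c(cc1OC)C(CC(=O)NCc1ccccc1)CC2` differs from compound 3 at the same position, (benzyl in place of cyclopentyl on an amide-type nitrogen). Going by the values given here, all three measured steps vary this amide nitrogen, and only the cyclopentyl step moved the number beyond the scatter; no measured step replaces one carbon ring by another, so the benzyl exchange has no direct precedent. Compound 4 is therefore expected to stay near compound 3, with a step of a number 2.7 percentage points lower from compound 3 to compound 4 (within the scatter), not beyond the scatter. The estimate for compound 4 is 38%, range 24% to 54%.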

Compound 4, a percentage reported as inhibition, in the whole organism at one dose (the size of the read-out at that dose, not a potency): 30.6%
The estimate for compound 4 lay 7.4 percentage points above the measured number, within the range that was stated.
By their numbers in this assay, from the lowest: compounds 2, 1 and 4 (each within the scatter of the next, the first and the last beyond it); then compound 3.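

In this assay, the carbon ring on the amide-type nitrogen is not interchangeable: benzyl in place of cyclopentyl gives a step beyond the scatter (a number 10.1 percentage points lower from compound 3 to compound 4 (beyond the scatter)), so the gain seen with cyclopentyl does not extend to every ring-bearing group. Benzyl stays within the scatter of the amide hydrogen (a number 2.8 percentage points higher from compound 1 to compound 4 (within the scatter)), yet it lies beyond the scatter of ethyl (a number 10.2 percentage points higher from compound 2 to compound 4 (beyond the scatter)). No evidence at hand bears on this difference. Going by these compounds, whether cyclohexyl or phenethyl on this nitrogen would sit nearer compound 3 or compound 4 remains open.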